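The source may hold more compounds than are shown below. What is called first, only, known or untested is meant among the compounds shown, and "the series" means these compounds.

Compound 1 `Nc1scc(CN2CCN(c3cccc(Cl)c3Cl)CC2)c1C(=O)c1ccc(Cl)cc1` and compound 2 `Nc1scc(CN2CCN(c3cccc(C(F)(F)F)c3)CC2)c1C(=O)c1ccc(Cl)cc1` share one core and differ only in the aryl group that sits on the amine nitrogen of the ring. In an assay on CHO cells for displacement of a labelled ligand from adenosine receptor A3 (Homo sapiens), read by scintillation counting, with a stated time of 120 min, tested at 10 uM (on this read-out higher numbers stand for more inhibition at the one concentration tested (going by the name of the read-out) and lower numbers for less inhibition), compound 1 gives 0%, and in this assay compound 2 gives 0%. The step of no change at the digits printed from compound 1 to compound 2 (within the scatter) shows that exchanging one substituted phenyl for another left the read-out where it was. Compound 2 therefore stands level with compound 1 on the numbers available, and neither shows any measurable inhibition.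

Compound 3 `Nc1scc(CN2CCN(c3ccc(Cl)c(C(F)(F)F)c3)CC2)c1C(=O)c1ccc(Cl)cc1` continues from compound 2: chloro in place of hydrogen on an aromatic carbon. Within the data shown here, no measured step adds a chloro group in this way; the only step available, no change at the digits printed from compound 1 to compound 2 (within the scatter), varied the substituents on the same phenyl ring and produced no change beyond the scatter. Because that step no change at the digits printed from compound 1 to compound 2 (within the scatter) was flat, the expected step in this assay is a number 2 percentage points higher from compound 2 to compound 3 (within the scatter), meaning no change beyond the scatter. Compound 3 is estimated to give 2% in this assay, with a range from 0% to 15%.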

Compound 3, a percentage reported as inhibition, at one concentration (the size of the read-out at that concentration, not a potency): 3%
For compound 3 the middle estimate is 1 percentage points below the measured one; the measured number falls inside the stated range.
By their numbers in this assay, from the lowest: compounds 1, 2 and 3 (each within the scatter of the next).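

In this assay, placing a chloro group on an aromatic carbon, ortho to a trifluoromethyl group and para to a large group, gives a number 3 percentage points higher from compound 2 to compound 3 (within the scatter), so this position can carry the extra atom without the read-out leaving the scatter. The comparison with the dichlorinated ring gives a number 3 percentage points higher from compound 1 to compound 3 (within the scatter), which means that 4-chloro-3-(trifluoromethyl)phenyl cannot be told apart from 2,3-dichlorophenyl here, and all three aryl groups shown sit together at the very bottom of this read-out at the one concentration tested. Nothing further is available that would explain these numbers.

From the compounds shown here alone, with all the values this close to the bottom of the scale, the chloro group cannot be said to help or to harm, and it remains open whether a different kind of group at this position, such as an amine or a carboxylic acid, would produce clear inhibition. Going by these compounds, it also remains open whether a change elsewhere on the shared core, such as a longer chain in place of the aryl group on the ring nitrogen, would move the read-out beyond the scatter.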